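The compounds below may be only part of what the source reports. "The series", "measured", "known", "first", "only" and "open" are said of these compounds alone.

Measured compounds:
- compound 1, `CC(=O)Nc1ccc(S(=O)(=O)Oc2ccccc2C(C)C)cc1`, with 12000 nM in a functional assay on HT-1080 cells (Homo sapiens) for antiproliferative activity, read by sulforhodamine B assay, with a stated time of 48 h; on this read-out higher numbers stand for weaker inhibition and lower numbers for stronger inhibition
- compound 2, `CCC(=O)Nc1ccc(S(=O)(=O)Oc2ccccc2C(C)C)cc1`, with 2100 nM in this assay
- compound 3, `CCC(=O)Nc1ccc(S(=O)(=O)Oc2ccccc2I)cc1`, with 7200 nM in this assay

Among these three numbers compound 2 holds the lowest value, with compound 3 nearest and compound 1 furthest. The step of a 5.7-fold lower number from compound 1 to compound 2 (0.76 log units; beyond the scatter) lies beyond the scatter, as does the step of a 3.4-fold higher number from compound 2 to compound 3 (0.54 log units; beyond the scatter).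

Compound 4, `CCCC(=O)Nc1ccc(S(=O)(=O)Oc2ccccc2C(C)C)cc1`, is not yet measured. It differs from compound 2 by methyl in place of hydrogen on a saturated chain carbon, two bonds along the chain from a carbonyl carbon, which extends the chain on the amide by one carbon, so that the propanoyl group of compound 2 becomes a propylcarbonyl group.

Among the measured compounds shown here, only one measured step bears directly on this change: the step of a 5.7-fold lower number from compound 1 to compound 2 (0.76 log units; beyond the scatter), which also lengthened that same chain by a single carbon and brought a modest improvement. The step of a 3.4-fold higher number from compound 2 to compound 3 (0.54 log units; beyond the scatter) concerns a different part of the molecule and says nothing about the chain. For the measured compounds named here, on the strength of the one step from compound 1 to compound 2, a further small gain is expected, though whether a second homologation repeats that gain cannot be read from the numbers in hand, and a result within the scatter is also plausible. Compound 4 is therefore expected to give about 1500 nM in this assay, with a range from 500 nM to 4500 nM, meaning an expected step of a 1.4-fold lower number from compound 2 to compound 4 (0.15 log units; within the scatter).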

Compound 4, half-maximal inhibitory concentration: 950 nM
Compound 4: the middle estimate sits 1.6-fold (0.20 log units) above what was measured; the range from low to high includes it.
By their numbers in this assay, from the lowest: compound 4; then compound 2; then compounds 3 and 1 (each within the scatter of the next).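

In this assay, the chain on the amide still matters at its new end: a 2.2-fold lower number from compound 2 to compound 4 (0.34 log units; beyond the scatter) lies beyond the scatter, so the benefit of lengthening the amide chain does not end at the propanoyl group. With the isopropyl group held constant, the numbers fall at each lengthening from compound 1 through compound 2 to compound 4, and none of these three goes against that trend. Taken as a single change, the two lengthenings together give a 13-fold lower number from compound 1 to compound 4 (1.10 log units; beyond the scatter), a large step that shows how much this one chain can shift the read-out on the shared core, although nothing available here accounts for the trend.

The compounds shown leave open whether a longer chain, such as pentanoyl or hexanoyl, would lower the number further or whether the trend stops at propylcarbonyl. They also leave open how a branched group such as isobutyryl or a ring-bearing group such as cyclopropylcarbonyl would compare, and whether propylcarbonyl brings a similar gain when iodo replaces isopropyl.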